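This account rests on a few compounds, and the source may have more. Where it says the series, first, only, none or still open, it means among the compounds named here.

In an ADME assay on Vero cells (Chlorocebus sabaeus) for cytotoxicity (a higher number here means that more compound is needed for the effect, a lower number that less compound is needed), compound 1 `COc1cc(Nc2nccc(N(C)C)n2)ccc1F` gives > 50100 nM, which is a limit of the assay and not a number. Compound 2 `COc1cc(Nc2nc(CO)cc(N(C)C)n2)ccc1F` gives > 50100 nM, also only a limit. All the evidence on this assay is the limit of > 50100 nM in this assay, at which 2 of the 2 values shown sit. Compound 3 `COc1cc(Nc2nc(C(=O)N3CCCC3)cc(N(C)C)n2)ccc1F` carries (pyrrolidin-1-yl)carbonyl in place of hydroxymethyl on an aromatic carbon. Within the data shown here, the only measured step, a step that the two limits leave unreadable from compound 1 to compound 2, has no readable size, so it offers no direction and no step beyond the scatter is expected. The expected change is a number no higher from compound 2 to compound 3 (the limit leaves the size open). For compound 3 the estimate is 50100 nM, with an expected range of 20000 nM to 80000 nM.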

Compound 3, half-maximal effective concentration in the Vero assay: > 50100 nM
Compound 3 gave a limit, no number; the forecaster's own chance of this, stated with the estimate: 85%; the middle value sits exactly at the limit.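

Among these compounds, no step among compound 1, compound 2 and compound 3 can be read in the Vero assay, where all three give only a limit: the limit of > 50100 nM in the Vero assay, at which 3 of the 3 values shown sit. In the Vero assay compound 3 gives > 50100 nM, which is a limit of the assay and not a number. In a physicochemical assay for solubility, read by nephelometry, measured as kinetic solubility (a lower number here means a less soluble compound, a higher number a more soluble compound), compound 2 gives > 250000 nM, which is a limit of the assay and not a number. In the physicochemical assay compound 3 gives > 250000 nM, which is also a limit of the assay and not a number. The compounds shown leave open the actual number behind each limit, in the Vero assay and in the physicochemical assay.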